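Diethylamino for methyl: cytotoxicity expectation in the series

The compounds below may be only part of what the source reports. "The series", "measured", "known", "first", "only" and "open" are said of these compounds alone.

For the measured compounds named here, compound 1 `Cc1ccc(C(=O)NC(=O)c2ccccc2O)cc1` is measured in an ADME assay on L6 cells (Rattus norvegicus) for cytotoxicity, read by resazurin assay, with a stated time of 72 h (a lower number here means a stronger inhibitor, a higher number a weaker inhibitor), at 46 ug/mL; of the two numbers so far compound 1 holds the lower, though its step to compound 2 `O=C(NC(=O)c1ccccc1O)c1ccc(OC(F)(F)F)cc1`, which gives 84 ug/mL, is a 1.8-fold higher number from compound 1 to compound 2 (0.26 log units; within the scatter). Compound 3 `CCN(CC)c1ccc(C(=O)NC(=O)c2ccccc2O)cc1` differs from compound 1 by diethylamino in place of methyl on an aromatic carbon. Going by the values given here, the single measured step, from compound 1 to compound 2, also exchanges a group on an aromatic carbon and stays within the scatter, so no step beyond the scatter is expected in this assay. Compound 3 is therefore estimated at 50 ug/mL, range 25 ug/mL to 100 ug/mL, which means an expected 1.1-fold higher number from compound 1 to compound 3 (0.04 log units; within the scatter).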

Compound 3, half-maximal inhibitory concentration: 8.2 ug/mL
Beside the measured number, compound 3's estimate is 6.1-fold (0.79 log units) above it; measured number below the stated range.
By their numbers in this assay, from the lowest: compound 3; then compounds 1 and 2 (each within the scatter of the next).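

The aromatic carbon para to a large group is not indifferent to its substituent in this assay: diethylamino gives a step beyond the scatter both against methyl (a 5.6-fold lower number from compound 1 to compound 3 (0.75 log units; beyond the scatter)) and against trifluoromethoxy (a 10-fold lower number from compound 2 to compound 3 (1.01 log units; beyond the scatter)). Methyl and trifluoromethoxy had stayed within the scatter of each other, so the earlier pair gave no sign of this sensitivity. The compounds shown leave open whether the nitrogen or the ethyl chains carry the shift, a question that dimethylamino or a ring amine such as piperidine would address. No measurement available here explains the shift.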